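The source may report more compounds than this note shows. Statements on the series, on what has been measured and on what is new or still open speak of the compounds shown alone.

Measured in a functional assay on A549 cells (Homo sapiens) for antiproliferative activity, read by MTT assay, with a stated time of 72 h; on this read-out lower numbers stand for stronger inhibition and higher numbers for weaker inhibition:
- compound 1 `O=C1COc2ccc(-c3cccc(NS(=O)(=O)c4ccc(F)cc4)c3)cc2N1`: 32100 nM
- compound 2 `COc1ncc(-c2ccc3c(c2)NC(=O)CO3)cc1NS(=O)(=O)c1ccc(F)cc1`: 8070 nM
- compound 3 `O=C1COc2ccc(-c3cnc(Cl)c(NS(=O)(=O)c4ccc(F)cc4)c3)cc2N1`: > 40000 nM (a limit of the assay, not a number)

Of the two real numbers, compound 1 holds the higher, 32100 nM, against 8070 nM for compound 2, a gap beyond the usual scatter. So compound 1 is a weak inhibitor here.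

The next molecule, compound 4 `O=C1COc2ccc(-c3cccc(NS(=O)(=O)c4ccc(F)cc4)c3)cc2N1c1ccc(Cl)cc1`, carries 4-chlorophenyl in place of hydrogen on an amide-type nitrogen in a ring.

Among the measured compounds shown here, no measured step touches that nitrogen. The only one, an at least 4.9-fold higher number from compound 2 to compound 3 (0.69 log units; beyond the scatter), is chloro in place of methoxy, so it bears only indirectly, showing that a single swap can move this read-out beyond the scatter. Compound 1 at 32100 nM also already holds the higher of the two real numbers, so a fall looks likelier than a rise.

The expected change is modest and uncertain: a 2.7-fold lower number from compound 1 to compound 4 (0.43 log units; beyond the scatter).

For compound 4 the estimate is 12000 nM, with an expected range from 3000 nM to 40000 nM.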

Compound 4, half-maximal inhibitory concentration: 31600 nM
Beside the measured number, compound 4's estimate is 2.6-fold (0.42 log units) below it; the range from low to high includes it.
By their numbers in this assay, from the lowest: compound 2; then compounds 4 and 1 (each within the scatter of the next). At a limit, above all of these: compound 3.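

Among the compounds shown here, on the amide-type nitrogen in the ring, which no earlier step touched, the hydrogen can give way to a whole 4-chlorophenyl ring with no effect on the read-out in this assay: a 1.0-fold lower number from compound 1 to compound 4 (0.01 log units; within the scatter). At this position, then, adding this aromatic ring brings neither a gain nor a loss, which a single swap elsewhere, the chloro for methoxy step, did not suggest. The read-out also has a ceiling, which matters for any weak compound on this core: the limit of > 40000 nM in this assay, at which 1 of the 4 values shown sits.

As far as these compounds go, whether a methyl group, or a short chain ending in an amine, on the same nitrogen would move the number remains open, since one substituent says little about a whole position. From the compounds shown here alone, it is also open whether 4-chlorophenyl at this nitrogen would behave the same way on the core of compound 2.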